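A Methoxy Step Repeated in a Glioblastoma Cytotoxicity Series

The source may report more compounds than this note shows. Statements on the series, on what has been measured and on what is new or still open speak of the compounds shown alone.

Compound 1 `COc1cc(-c2cc(/C=C/C(=O)c3ccc(N)cc3)[nH]n2)cc(OC)c1OC`: -96%
Compound 2 `COc1ccc(C(=O)/C=C/c2cc(-c3cc(OC)c(OC)c(OC)c3)n[nH]2)cc1OC`: -100%
Compound 3 `COc1ccc(-c2cc(/C=C/C(=O)c3ccc(N)cc3)[nH]n2)cc1OC`: -68%

These three values come from a functional assay on U-251 cells (Homo sapiens) for cytotoxicity, read by sulforhodamine B assay, with a stated time of 48 h, tested at 10 uM; a lower number here means a stronger effect, a higher number a weaker effect of the compound at the concentration tested. Compound 3 and compound 1 differ by methoxy in place of hydrogen on an aromatic carbon, and that change gave a number 28 percentage points lower from compound 3 to compound 1 (beyond the scatter). Compound 1 and compound 2 differ on the carbonyl carbon, a change that gave a number 4 percentage points lower from compound 1 to compound 2 (within the scatter). How the core of compound 2 differs from the core of compound 3 is not broken down here.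

Compound 4 `COc1cc(C(=O)/C=C/c2cc(-c3cc(OC)c(OC)c(OC)c3)n[nH]2)cc(OC)c1OC` is not yet measured. It differs from compound 2 by methoxy in place of hydrogen on an aromatic carbon, the same change that separates compound 3 from compound 1; among these compounds it occurs twice. In this assay the step from compound 2 to compound 4 is expected to be a number 1 percentage points higher from compound 2 to compound 4 (within the scatter), much smaller than the earlier one, because compound 2 already gives -100% and little room remains. Compound 4 is therefore estimated at -99%, between -105% and -85%.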

Compound 4, a percentage reported as activity, at one concentration (the size of the read-out at that concentration, not a potency): -94%
Beside the measured number, compound 4's estimate is 5 percentage points below it, within the range that was stated.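

In this assay, methoxy in place of hydrogen on an aromatic carbon gave a number 6 percentage points higher from compound 2 to compound 4 (within the scatter), and this step did not match the one seen on the other core: the same change on two cores in this assay, a number 28 percentage points lower (beyond the scatter) from compound 3 to compound 1 and a number 6 percentage points higher (within the scatter) from compound 2 to compound 4, 34 percentage points apart, beyond the scatter of two such steps Across these two pairs, then, the change did not carry over as a step of fixed size. From the compounds shown here alone, the pairs do not show what sets the gap between the two steps, and a reading at one concentration gives no potency, so any difference between compound 2 and compound 4 at lower concentrations remains unknown.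

The compounds shown leave open how other groups would behave at this place on the aromatic ring. A hydroxy group, a fluorine atom or a longer chain such as ethoxy could each be set in place of the methoxy.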